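This account rests on a few compounds, and the source may have more. Where it says the series, first, only, none or still open, it means among the compounds named here.

Three compounds of this series have a number in a functional assay on PC-3 cells (Homo sapiens) for cytotoxicity, read by sulforhodamine B assay, with a stated time of 48 h; a higher number here means a weaker inhibitor, a lower number a stronger inhibitor. Compound 1 `CC(=O)N1N=C(c2ccccc2)CC1c1ccc(N(C)C)cc1` gives 7880 nM in this assay, compound 2 `CC(=O)N1N=C(c2ccco2)CC1c1ccccc1[N+](=O)[O-]` gives 19000 nM, and compound 3 `CC(=O)N1N=C(c2cccc3ccccc23)CC1c1cccc(Cl)c1Cl` gives 20100 nM. Compound 3 has the highest of the three numbers; its gap to compound 2 is within the scatter, its gap to compound 1 is beyond it. Compound 4 `CC(=O)N1N=C(c2cccc3ccccc23)CC1/C=C/c1ccccc1` has not been measured. It differs from compound 3 by 2-phenylethenyl in place of 2,3-dichlorophenyl on a saturated ring carbon. Going by the values given here, no measured pair of the series isolates this exchange, so the step from compound 3 to compound 4 in this assay is expected to be a 1.1-fold lower number from compound 3 to compound 4 (0.05 log units; within the scatter), not beyond the scatter. Compound 4 is therefore estimated at 18000 nM in this assay, with a range from 6000 nM to 50000 nM.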

Compound 4, half-maximal inhibitory concentration: 21100 nM
Compound 4: middle estimate off by 1.2-fold (0.07 log units), on the low side, and the stated range covers the measured number.
By their numbers in this assay, from the lowest: compound 1; then compounds 2, 3 and 4 (each within the scatter of the next).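

In this assay, 2-phenylethenyl in place of 2,3-dichlorophenyl on the saturated ring carbon gives a 1.0-fold higher number from compound 3 to compound 4 (0.02 log units; within the scatter), the only single-place comparison shown in the series. In this pair, the two groups are not separated at this position: removing both chlorines and adding a double bond outside aromatic rings leaves the number within the scatter. Nothing available explains this result. Still open, going by these compounds, is whether an amine or a carboxylic acid on this carbon would separate from these values. Also open, on these data alone, is whether the same exchange gives a similar step on the cores of compound 1 and compound 2.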